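Methylating the carbamate nitrogen of compound 2

A few compounds are considered here, and "the series" means these few. Any claim that something is new, unique, unknown or untested is made for them only; others in the source may bear on it.

compound 1 `CCOC(=O)c1cccc(-c2ccc(N(C)C)cc2)c1` — in an assay on COS-7 cells for inhibition of patatin-like phospholipase domain-containing protein 2 (Mus musculus) (a higher number here means a weaker inhibitor, a lower number a stronger inhibitor), compound 1 gives 40000 nM
compound 2 `CCOC(=O)Nc1cccc(-c2ccc(N(C)C)cc2)c1` — in this assay compound 2 gives 3000 nM

Compound 2 stands lowest of the two numbers in this assay, set apart from compound 1 by a 13-fold lower number from compound 1 to compound 2 (1.12 log units; beyond the scatter). Compound 3 `CCOC(=O)N(C)c1cccc(-c2ccc(N(C)C)cc2)c1` differs from compound 2 by methyl in place of hydrogen on an amide-type nitrogen. Among the measured compounds shown here, no measured step touches that amide-type nitrogen; the only step, a 13-fold lower number from compound 1 to compound 2 (1.12 log units; beyond the scatter), concerns the exchange of ethoxycarbonyl for (ethoxycarbonyl)amino and gives no guide for methylation there. For compound 3 the expected step is a 1.3-fold higher number from compound 2 to compound 3 (0.12 log units; within the scatter), nothing beyond the scatter. Compound 3 is thus estimated at 4000 nM, with a range of 1000 nM to 15000 nM.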

Compound 3, half-maximal inhibitory concentration: > 200000 nM
Compound 3: no number, only a limit (the forecaster's own chance of this, stated with the estimate: 10%); at least 50-fold (1.69 log units) between middle value and limit.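

Compound 3 gives no number in this assay, only a limit: the limit of > 200000 nM in this assay, at which 1 of the 3 values shown sits.

The amide-type nitrogen, untested by the earlier pair, proves highly sensitive to this change: methyl in place of hydrogen gives an at least 66-fold higher number from compound 2 to compound 3 (1.82 log units; beyond the scatter). The gain brought by (ethoxycarbonyl)amino does not survive methylation, since the comparison with the ester reads an at least 5.0-fold higher number from compound 1 to compound 3 (0.69 log units; beyond the scatter).

Open, as far as these compounds go, is whether any group on that nitrogen, such as ethyl, gives the same loss or whether it is specific to methyl. Also open, from the compounds shown here alone, is whether a urea in place of the carbamate keeps the number of compound 2.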